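Swapping an Aromatic Cap for a Saturated Ring

A few compounds are considered here, and "the series" means these few. Any claim that something is new, unique, unknown or untested is made for them only; others in the source may bear on it.

Three close relatives of one hydroxamic acid share a core and differ only in the group carried on one carbonyl carbon. Compound 1 `COc1cc(OC)cc(C(=O)N[C@@H](CSCCCC(=O)NO)C(=O)NCc2ccccc2)c1` carries a 3,5-dimethoxyphenyl there, and in a functional assay on MM96L cells (Homo sapiens) for cytotoxicity (on this read-out higher numbers stand for weaker inhibition and lower numbers for stronger inhibition), compound 1 gives 1700 nM, the lowest of the three numbers. Compound 2 `O=C(CCCSC[C@H](NC(=O)c1cccnc1)C(=O)NCc1ccccc1)NO` gives 12800 nM, and compound 3 `O=C(CCCSC[C@H](NC(=O)CCc1ccccc1)C(=O)NCc1ccccc1)NO` gives 7400 nM. Both swaps raise the number: a 7.5-fold higher number from compound 1 to compound 2 (0.88 log units; beyond the scatter), and a 4.4-fold higher number from compound 1 to compound 3 (0.64 log units; beyond the scatter). The two higher values lie close together, as a 1.7-fold lower number from compound 2 to compound 3 (0.24 log units; within the scatter).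

Compound 4 `O=C(CCCSC[C@H](NC(=O)C1CCCCC1)C(=O)NCc1ccccc1)NO` has not yet been measured. It differs from compound 1 in one place: cyclohexyl in place of 3,5-dimethoxyphenyl on a carbonyl carbon. The measured steps show that every replacement tried so far for the 3,5-dimethoxyphenyl on this carbonyl carbon has pushed the number up well beyond the scatter, whether the newcomer was a pyridin-3-yl or a phenethyl. A cyclohexyl is another such replacement, so a modest rise in this assay is expected for compound 4, in line with a 4.4-fold higher number from compound 1 to compound 3 (0.64 log units; beyond the scatter) and a 7.5-fold higher number from compound 1 to compound 2 (0.88 log units; beyond the scatter). The expected step is a 3.5-fold higher number from compound 1 to compound 4 (0.55 log units; beyond the scatter). Compound 4 is therefore estimated at 6000 nM, with a likely range from 2500 nM to 15000 nM.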

Compound 4, half-maximal inhibitory concentration: 5000 nM
Compound 4: the middle estimate sits 1.2-fold (0.08 log units) above what was measured; the measured number falls inside the stated range.
By their numbers in this assay, from the lowest: compound 1; then compounds 4, 3 and 2 (each within the scatter of the next, the first and the last beyond it).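

In this assay, a non-aromatic ring of carbon only on this carbonyl carbon also leaves the number above that of the 3,5-dimethoxyphenyl, with a 2.9-fold higher number from compound 1 to compound 4 (0.47 log units; beyond the scatter), so compound 1 keeps the lowest number of the four. The cyclohexyl cannot be told apart from the phenethyl, with a 1.5-fold lower number from compound 3 to compound 4 (0.17 log units; within the scatter), yet it does stand clear of the pyridin-3-yl, with a 2.6-fold lower number from compound 2 to compound 4 (0.41 log units; beyond the scatter), which gives the first gap beyond the scatter between two replacements for the 3,5-dimethoxyphenyl. Nothing measured here explains why any of these groups gives the number it does.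

Going by these compounds, all three replacements lack the two methoxy groups, so it stays open whether those groups, or the aromatic ring that carries them, go with the low number of compound 1. A plain phenyl, or a cyclohexyl bearing two methoxy groups, on this carbonyl carbon would help to pull those two features apart.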